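This account rests on a few compounds, and the source may have more. Where it says the series, first, only, none or still open, it means among the compounds named here.

In a functional assay on HepG2 cells (Homo sapiens) for cytotoxicity, with a stated time of 72 h (on this read-out higher numbers stand for an effect only at larger amounts of compound and lower numbers for an effect already at smaller amounts), compound 1 (`C=C[C@@](C)(/C=C/c1ccc(Nc2ccccc2)cc1)CCC=C(C)C`) gives > 52000 nM, which is a limit and not a number. Compound 2 (`C=C[C@@](C)(/C=C/c1ccc(Nc2ccc(OC)cc2)cc1)CCC=C(C)C`) gives > 52000 nM, also a limit and not a number. Among the compounds with values here, the series so far therefore stands at the limit of > 52000 nM in this assay, at which 2 of the 2 values shown sit. Within the data shown here, the only measured step is a step that the two limits leave unreadable from compound 1 to compound 2, with methoxy in place of hydrogen on an aromatic carbon, so it supplies no size to carry forward. Compound 3 (`C=C[C@@](C)(/C=C/c1ccc(Nc2ccc(OC(F)(F)F)cc2)cc1)CCC=C(C)C`) changes one place in compound 2: trifluoromethyl in place of methyl on an oxygen on an aromatic ring. With no readable step to draw on, no change beyond the scatter is expected in this assay, and the read-out will most likely remain a limit. The expected size is a number no higher from compound 2 to compound 3 (the limit leaves the size open). For compound 3 the estimate is 52000 nM, with an expected range of 20000 nM to 100000 nM.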

Compound 3, half-maximal effective concentration: > 52000 nM
Compound 3: no number, only a limit; the forecaster's own chance of this, stated with the estimate: 70%; the middle value sits exactly at the limit.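

No step can be read among compound 1, compound 2 and compound 3 in this assay, since all three results are limits and not numbers: the limit of > 52000 nM in this assay, at which 3 of the 3 values shown sit. The compounds shown leave open whether hydrogen, methoxy and trifluoromethoxy differ at all here, and at what concentration any of these compounds would act.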